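The compounds below may be only part of what the source reports. "The series", "measured", "known", "first", "only" and "open" are said of these compounds alone.

Compound 1 `CCCCCCCN1CCC(C(=O)Nc2cc(Cl)c(N)cc2OC)CC1` — > 10 mg/kg
Compound 2 `COc1cc(N)c(Cl)cc1NC(=O)C1CCN(CC2CC2)CC1` — > 10 mg/kg

All the numbers come from a functional assay on the whole organism for antagonist activity, with Mus musculus as the target; a higher number here means that more compound is needed for the effect, a lower number that less compound is needed. In this assay compound 1 gives only a limit, > 10 mg/kg. Compound 2 likewise gives only a limit, > 10 mg/kg. Because both values sit at the limit of > 10 mg/kg in this assay, at which 2 of the 2 values shown sit, the step that the two limits leave unreadable from compound 1 to compound 2 cannot be read, so the exchange of hexyl for cyclopropyl tells nothing about size or direction. Compound 3 `COc1cc(N)c(Cl)cc1NC(=O)C1CCN(Cc2cccc(C)c2)CC1` has not yet been measured; it differs from compound 2 by 3-methylphenyl in place of cyclopropyl on a saturated chain carbon bound to an amine nitrogen in a ring. Within the data shown here, no measured step bears directly on this change, and the single step that exists is unreadable. Among the measured compounds shown here, the only guide is that compound 2 reached the limit, so the expectation for compound 3 is a similar position rather than a step in either direction beyond the scatter. The expected step is a number no higher from compound 2 to compound 3 (the limit leaves the size open). Compound 3 is expected to give about 10 mg/kg, in a range from 3 mg/kg to 40 mg/kg, with a real chance that this assay again reports only a limit.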

Compound 3, dose for half-maximal effect: 2.4 mg/kg
Compound 3: the middle estimate sits 4.2-fold (0.62 log units) above what was measured; the whole stated range lies above it.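

In this assay, the saturated chain carbon bound to the amine nitrogen in a ring now gives a readable answer: putting 3-methylphenyl in place of cyclopropyl gives an at least 4.1-fold lower number from compound 2 to compound 3 (0.61 log units; beyond the scatter), and putting it in place of hexyl gives an at least 4.1-fold lower number from compound 1 to compound 3 (0.61 log units; beyond the scatter). So the group at this place can change the dose needed, and 3-methylphenyl is the one group shown that brings the number to a measured value, while the cyclopropyl and hexyl compounds give only a limit. The step between compound 1 and compound 2 still cannot be read, and the two new steps give only a smallest possible size because their starting compounds stand at a limit: the limit of > 10 mg/kg in this assay, at which 2 of the 3 values shown sit.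

Compound 3 brings in an aromatic ring, a methyl group and a larger count of heavy atoms all at once, so the compounds shown cannot tell which of these matters. On these data alone, whether a plain benzyl group, with no methyl on the ring, or a cyclohexylmethyl group, with a saturated ring of the same size, would also give a measured value remains open.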